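Swapping methoxy for chloro: expected tolerance of compound 4

The source may hold more compounds than are shown below. What is called first, only, known or untested is meant among the compounds shown, and "the series" means these compounds.

Of the compounds shown here, three sharing one core have been measured in an ADME assay on MT4 cells (Homo sapiens) for cytotoxicity, read by MTT assay, with a stated time of 5 days; a higher number here means that more compound is tolerated, a lower number that less compound is tolerated. Compound 1 `O=[N+]([O-])c1ccc(-c2nnc(-c3cccnc3)n2Nc2nc3ccc([N+](=O)[O-])cc3s2)cc1` carries a nitro group on the fused ring and gives 50.8 ug/mL. Compound 2 `Cc1ccc2nc(Nn3c(-c4ccc([N+](=O)[O-])cc4)nnc3-c3cccnc3)sc2c1` carries a methyl group at the same position and gives 64.4 ug/mL. Compound 3 `COc1ccc2nc(Nn3c(-c4ccc([N+](=O)[O-])cc4)nnc3-c3cccnc3)sc2c1` carries a methoxy group there and gives 12.9 ug/mL, the lowest of the three numbers. The step of a 1.3-fold higher number from compound 1 to compound 2 (0.10 log units; within the scatter) lies within the scatter, whereas a 3.9-fold lower number from compound 1 to compound 3 (0.60 log units; beyond the scatter) and a 5.0-fold lower number from compound 2 to compound 3 (0.70 log units; beyond the scatter) are both beyond it, so compound 3 stands apart from the other two as the least tolerated compound.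

Compound 4 `O=[N+]([O-])c1ccc(-c2nnc(-c3cccnc3)n2Nc2nc3ccc(Cl)cc3s2)cc1` differs from compound 3 in one place: chloro in place of methoxy on an aromatic carbon. Among the compounds with values here, no measured step involves a chloro group, so the expectation rests on what the three substituents already examined show. Two of them, nitro and methyl, give numbers close to each other, and only methoxy gives a lower one. Compound 4 is therefore expected to move back toward the range of compound 1 and compound 2, with a step of a 3.1-fold higher number from compound 3 to compound 4 (0.49 log units; beyond the scatter) in this assay. The estimate for compound 4 is 40 ug/mL, with a range from 15 ug/mL to 100 ug/mL.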

Compound 4, half-maximal cytotoxic concentration: 53.7 ug/mL
For compound 4 the middle estimate is 1.3-fold (0.13 log units) below the measured one, within the range that was stated.
By their numbers in this assay, from the lowest: compound 3; then compounds 1, 4 and 2 (each within the scatter of the next).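

In this assay the fourth substituent at this aromatic carbon sets compound 3 further apart, as chloro in place of methoxy gives a 4.2-fold higher number from compound 3 to compound 4 (0.62 log units; beyond the scatter), so the lower number of compound 3 does not extend to every group other than nitro and methyl. Chloro cannot be told from the other two groups, with a 1.2-fold lower number from compound 2 to compound 4 (0.08 log units; within the scatter) and a 1.1-fold higher number from compound 1 to compound 4 (0.02 log units; within the scatter), so compounds 1, 2 and 4 form one group despite carrying three different substituents, and compound 3, with methoxy, is the only one of the four that goes against this. The data shown offer no measurement that accounts for why methoxy alone stands apart.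

Going by these compounds, whether the low number belongs to methoxy alone or would also appear with a hydroxyl group, an ethoxy group or an amine at this carbon stays open. On these data alone, all four compounds also share the rest of the core, so it remains open whether methoxy would stand apart in the same way if another part of the structure were different.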